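This account rests on a few compounds, and the source may have more. Where it says the series, first, only, none or still open, it means among the compounds named here.

Of the compounds shown here, three have so far been measured in a functional assay on MCF7 cells (Homo sapiens) for antiproliferative activity, read by MTT assay, with a stated time of 72 h; a lower number here means a stronger inhibitor, a higher number a weaker inhibitor. Compound 1 `COc1ncc(-c2ccc3c(c2)NC(=O)CO3)cc1NS(=O)(=O)c1ccc(F)cc1` gives 32300 nM in this assay. Compound 2 `O=C1COc2ccc(-c3cccc(NS(=O)(=O)c4ccc(F)cc4)c3)cc2N1c1ccc(Cl)cc1` gives 39800 nM in this assay. Compound 3 `O=C1COc2ccc(-c3cccc(NS(=O)(=O)c4ccc(F)cc4)c3)cc2N1c1ccc(F)cc1` gives in this assay only a limit, > 40000 nM, so its true value is not known. Among the measured compounds shown here, the step from compound 2 to compound 3 is the only one between measured compounds that differ in one place; it reads a number no lower from compound 2 to compound 3 (the limit leaves the size open), and its size is not readable because of the limit of > 40000 nM in this assay, at which 1 of the 3 values shown sits. Compound 3 thus stands at the limit of this assay, with compound 1 and compound 2 not far from it.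

Compound 4 `O=C1COc2ccc(-c3cccc(NS(=O)(=O)c4ccc(F)cc4)c3)cc2N1C1CCCCC1` differs from compound 3 in one place: cyclohexyl in place of 4-fluorophenyl on an amide-type nitrogen in a ring. For the measured compounds named here, no measured step concerns this change; the only measured step swaps one halogen for another on an aromatic carbon. The two values that can be read, for compound 1 and compound 2, both lie close to the limit, and the step from compound 2 to compound 3 did not lower the number. The expectation for compound 4 is therefore a step that the limit leaves unreadable from compound 3 to compound 4, that is, no change beyond the scatter. Compound 4 is expected to give 45000 nM in this assay, within 15000 nM to 150000 nM, with a real chance that only a limit is reported.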

Compound 4, half-maximal inhibitory concentration: 21400 nM
Compound 4: the middle estimate sits 2.1-fold (0.32 log units) above what was measured; the range from low to high includes it.
By their numbers in this assay, from the lowest: compounds 4, 1 and 2 (each within the scatter of the next). At a limit, above all of these: compound 3.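

Among the compounds shown here, at the amide-type nitrogen in a ring, the earlier compounds showed only one halogen swapped for another on an aromatic ring, whereas compound 4 replaces that aromatic ring with the non-aromatic cyclohexyl, and in this assay this change gives a 1.9-fold lower number from compound 2 to compound 4 (0.27 log units; within the scatter). Starting from the 4-fluorophenyl group instead, the same kind of change gives an at least 1.8-fold lower number from compound 3 to compound 4 (0.27 log units; that floor lies within the scatter), and the true size of that step stays open because one end of it is a limit: the limit of > 40000 nM in this assay, at which 1 of the 4 values shown sits. Where the step can be read in full, an aromatic ring at this nitrogen is therefore not needed to hold the number at this level, since a ring of carbon without aromatic character serves as well within the scatter.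

Going by these compounds, all the groups compared at this nitrogen are six-membered rings of carbon, so it remains open whether a group without a ring, such as methyl or a longer chain, would move the number beyond the scatter. On these data alone, it is equally open whether a cyclohexyl carrying an amine or a carboxylic acid would do so.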